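A few compounds are considered here, and "the series" means these few. Any claim that something is new, unique, unknown or untested is made for them only; others in the source may bear on it.

Of the compounds shown here, three built on one shared core have been measured in a toxicity assay on THP-1 cells (Homo sapiens) for inhibition; a higher number here means that more compound is tolerated, a lower number that less compound is tolerated. Compound 1 `Cn1c(-c2ccc(C#N)cc2)cnc1NC(=O)c1ncc[nH]1` gives only a limit of the assay, > 100000 nM. Compound 3 `COc1ccc(-c2cnc(NC(=O)c3ccc(C)cc3)n2C)cc1` also gives only a limit, > 100000 nM. Compound 2 `Cn1c(-c2ccc(C#N)cc2)cnc1NC(=O)c1ccc(F)cc1` stands at a limit as well, > 50000 nM. The single step between measured compounds that differ in one place, a step that the two limits leave unreadable from compound 1 to compound 2, is left unreadable by the limits at both of its ends, which the limit of > 100000 nM in this assay, at which 2 of the 3 values shown sit, and the limit of > 50000 nM in this assay, at which 1 of the 3 values shown sits, describe; every value so far sits at a limit, so none of these compounds reached a measurable half-maximal cytotoxic concentration.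

Compound 4 `Cn1c(-c2ccc(Br)cc2)cnc1NC(=O)c1ccc(F)cc1` has not yet been measured. It differs from compound 2 in one place: bromo in place of cyano on an aromatic carbon. Going by the values given here, no measured step covers a bromo in place of a cyano, so nothing among the measured compounds speaks for or against a shift in this assay beyond the scatter, and the expectation rests on compound 2 alone, whose value is a limit. The expected step is a step that the limit leaves unreadable from compound 2 to compound 4, within the scatter. Compound 4 is therefore estimated at 60000 nM, with a range from 20000 nM to 150000 nM, and most likely will again be reported only as a limit.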

Compound 4, half-maximal cytotoxic concentration: 46000 nM
Compound 4: middle estimate off by 1.3-fold (0.12 log units), on the high side; the measured number falls inside the stated range.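

In this assay, bromo in place of cyano on the aromatic carbon gives an at least 1.0-fold lower number from compound 2 to compound 4 (0.03 log units; that floor lies within the scatter), a floor and not a measured size. Compound 4 is the first of the compounds shown to give a real number rather than a limit, so a half-maximal cytotoxic concentration can be read with this group on the ring. The true size of the step stays unknown, and the step between the 1H-imidazol-2-yl and 4-fluorophenyl compounds cannot be read either, because limits stand in place of numbers: the limit of > 50000 nM in this assay, at which 1 of the 4 values shown sits.

Still open, from the compounds shown here alone, is whether bromo is special at this place on the ring, or whether a chloro group, an amine or a carboxylic acid in place of the cyano would give a similar reading. Also open, going by these compounds, is what the same swap of cyano for bromo does when the carbonyl carbon carries the 1H-imidazol-2-yl of compound 1 rather than the 4-fluorophenyl of compound 4.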